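This account rests on a few compounds, and the source may have more. Where it says the series, first, only, none or still open, it means among the compounds named here.

Measured compounds:
compound 1, `COc1ccc(S(=O)(=O)NCCN2CCC(CCC(=O)c3cc(Cl)c(N)cc3OC)CC2)cc1Br`, 24.3 nM
compound 2, `COc1cc(N)c(Cl)cc1C(=O)CCC1CCN(CCNS(=O)(=O)c2ccc(C)cc2)CC1`, 18 nM
compound 3, `COc1cc(N)c(Cl)cc1C(=O)CCC1CCN(CCNS(=O)(=O)c2ccc(N)c(Br)c2)CC1`, 5.3 nM

In an assay on brain for displacement of a labelled ligand from 5-hydroxytryptamine receptor 4 (Cavia porcellus), with a stated time of 30 min, in the presence of a further agent that is not named here (on this read-out lower numbers stand for stronger inhibition and higher numbers for weaker inhibition), compound 1 gives the highest number of the three. Its nearest neighbour is compound 2, a step of a 1.4-fold lower number from compound 1 to compound 2 (0.13 log units; within the scatter), and the furthest is compound 3, a step of a 4.6-fold lower number from compound 1 to compound 3 (0.66 log units; beyond the scatter). Between compound 2 and compound 3 the step is a 3.4-fold lower number from compound 2 to compound 3 (0.53 log units; beyond the scatter).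

Compound 4, `COc1cc(N)c(Cl)cc1C(=O)CCC1CCN(CCNS(=O)(=O)c2ccc(OC)c(N3CCN(C)CC3)c2)CC1`, differs from compound 1 at the aryl group on the sulfonyl sulfur: 4-methylpiperazin-1-yl in place of bromo on an aromatic carbon. Within the data shown here, none of the measured steps exchanges a bromo for a piperazine, so none bears on it directly. What they do show is that this aryl group can be altered with little effect, as in a 1.4-fold lower number from compound 1 to compound 2 (0.13 log units; within the scatter), or with a modest gain, as in a 4.6-fold lower number from compound 1 to compound 3 (0.66 log units; beyond the scatter) and a 3.4-fold lower number from compound 2 to compound 3 (0.53 log units; beyond the scatter). Compound 4 is therefore expected to stay close to compound 1 or to improve modestly, with a step of a 1.6-fold lower number from compound 1 to compound 4 (0.21 log units; within the scatter) in this assay. The estimate for compound 4 is 15 nM, with a range from 4 nM to 60 nM.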

Compound 4, inhibition constant: 3.46 nM
Compound 4: the middle estimate sits 4.3-fold (0.64 log units) above what was measured, outside the stated range (below it).
By their numbers in this assay, from the lowest: compounds 4 and 3 (each within the scatter of the next); then compounds 2 and 1 (each within the scatter of the next).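

In this assay the bromo on the aromatic carbon ortho to a methoxy group gives way to 4-methylpiperazin-1-yl, and the result is a 7.0-fold lower number from compound 1 to compound 4 (0.85 log units; beyond the scatter) with the rest of compound 1 unchanged. Among these compounds, the earlier steps either kept the bromo or removed it along with the methoxy group, so this is the first view of a change at this position alone, and it shows that a single bromine atom can be replaced by a group of 7 heavy atoms carrying a six-membered non-aromatic ring without any loss on this read-out. No measurement at hand explains why the number falls, so the gain stands here as an observation only.

The compounds shown leave open whether the gain depends on the whole 4-methylpiperazin-1-yl group or on only a part of it, a question that a morpholin-4-yl group, a piperazine without the methyl group or an open-chain dimethylamino group at this position would address. They also leave open whether the gain depends on the methoxy group ortho to this position, which a hydrogen or an ethoxy group in its place would test.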